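Phenyl for thiophen-3-yl in a series of limits

The compounds below may be only part of what the source reports. "The series", "measured", "known", "first", "only" and "open" are said of these compounds alone.

Compound 3 `Cc1nc(N)c2c(-c3ccsc3)cn([C@@H]3O[C@H](CO)[C@@H](O)[C@H]3O)c2n1` stands only at a limit of a functional assay on HL-60 cells (Homo sapiens) for antiproliferative activity, read by XTT assay, with a stated time of 72 h; on this read-out lower numbers stand for stronger inhibition and higher numbers for weaker inhibition: compound 3 gives > 20000 nM, which is a limit and not a number. Compound 1 `Nc1nc(N)c2c(-c3ccsc3)cn([C@@H]3O[C@H](CO)[C@@H](O)[C@H]3O)c2n1` likewise gives > 20000 nM, a limit. Compound 2 `COc1nc(N)nc2c1c(-c1cc3ccccc3o1)cn2[C@@H]1O[C@H](CO)[C@@H](O)[C@H]1O` gives > 20000 nM, again a limit. Hence the one step with a single change, a step that the two limits leave unreadable from compound 1 to compound 3, has no readable size, and the limit of > 20000 nM in this assay, at which 3 of the 3 values shown sit, is all the series offers. Compound 4 `Cc1nc(N)c2c(-c3ccccc3)cn([C@@H]3O[C@H](CO)[C@@H](O)[C@H]3O)c2n1` differs from compound 3 in one place: phenyl in place of thiophen-3-yl on an aromatic carbon. Among the compounds with values here, no measured step bears on this change, so nothing beyond the scatter is expected in this assay. Compound 4 is therefore expected to give about 25000 nM (range 8000 nM to 80000 nM), most probably again as a limit. The step that the limit leaves unreadable from compound 3 to compound 4 that this estimate means is expected to be small.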

Compound 4, half-maximal inhibitory concentration: > 20000 nM
Compound 4: no number, only a limit; the forecaster's own chance of this, stated with the estimate: 75%; the middle value is on the limit's open side.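

No step can be read between compound 3 and compound 4, since both stand only at a limit in this assay: the limit of > 20000 nM in this assay, at which 4 of the 4 values shown sit. On these data alone, whether phenyl or thiophen-3-yl on the shared core makes any difference to antiproliferative activity stays open.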